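A few compounds are considered here, and "the series" means these few. Any claim that something is new, unique, unknown or untested is made for them only; others in the source may bear on it.

Of the compounds shown here, three have been measured so far in a functional assay on MCF7 cells (Homo sapiens) for antiproliferative activity, read by MTT assay, with a stated time of 72 h; on this read-out lower numbers stand for stronger inhibition and higher numbers for weaker inhibition. Compound 1 `CCN(CC)CCNC(=O)c1ccc(C(CC)(CC)c2ccc(OCC(O)C(C)(C)C)c(C)c2)n1CC` gives 1370 nM there, compound 2 `CCn1c(C(=O)N[C@H](C(=O)O)C(C)C)ccc1C(CC)(CC)c1ccc(C#CC(O)(CC)CC)c(C)c1` gives 13000 nM and compound 3 `CCn1cc(C(CC)(CC)c2ccc(C#CC(O)(CC)CC)c(C)c2)cc1C(=O)NCCCN(C)C` gives 20200 nM in the same test. Compound 3 therefore stands within the scatter of compound 2, and beyond the scatter of compound 1, which has the lower number. Compound 4 `CCn1cc(C(CC)(CC)c2ccc(C#CC(O)(CC)CC)c(C)c2)cc1C(=O)NCCC(=O)O` has not yet been measured. It differs from compound 3 by one change, (carboxy in place of (dimethylamino)methyl on a saturated chain carbon, two bonds along the chain from an amide-type nitrogen), with carboxy in place of (dimethylamino)methyl on a saturated chain carbon, two bonds along the chain from an amide-type nitrogen. Within the data shown here, no measured pair shows this change alone, so the forecast is loose. Compound 2 also carries a carboxy group, and at 13000 nM it does not separate from compound 3 beyond the scatter, though the two differ elsewhere too. In this assay no step beyond the scatter is therefore expected, in either direction. The expected step of a 1.1-fold higher number from compound 3 to compound 4 (0.04 log units; within the scatter) is small. For compound 4 the estimated value is 22000 nM, with an expected range from 9000 nM to 50000 nM.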

Compound 4, half-maximal inhibitory concentration: 30600 nM
For compound 4 the middle estimate is 1.4-fold (0.14 log units) below the measured one; measured number inside the range.
By their numbers in this assay, from the lowest: compound 1; then compounds 2, 3 and 4 (each within the scatter of the next, the first and the last beyond it).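

In this assay, among these compounds, carboxy in place of (dimethylamino)methyl on a saturated chain carbon, two bonds along the chain from an amide-type nitrogen, gives a 1.5-fold higher number from compound 3 to compound 4 (0.18 log units; within the scatter), the first direct reading of this change. At this position, the group with the amine and the group with the acid therefore do not separate beyond the scatter, even though the carboxy brings a hydrogen-bond donor and the group it replaces has none. Nothing available here explains the size of this step.

The compounds shown leave open whether a primary amide or a hydroxyl in place of the carboxy, or a longer chain carrying the carboxy, would separate from compound 3 in this assay. They also leave open what step this same change would give on the core of compound 1.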